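From pyrrolidin-1-yl to cyclopentylamino on the shared core

The source may hold more compounds than are shown below. What is called first, only, known or untested is meant among the compounds shown, and "the series" means these compounds.

Two compounds built on one shared core have been put through an ADME assay on MOLT-3 cells (Homo sapiens) for cytotoxicity, with a stated time of 7 days (on this read-out lower numbers stand for higher toxicity in this test and higher numbers for lower toxicity in this test), so far. In this assay compound 1 (`Nc1nc(OCc2ccccc2)c2ncn(/C=C3/CC3(CO)CO)c2n1`) gives > 20000 nM as its result, and that result is a limit of the assay and not a number. In this assay compound 2 (`Nc1nc(N2CCCC2)c2ncn(/C=C3/CC3(CO)CO)c2n1`) gives "not determined" (no result reported) as its entry, so it has no place on the scale yet. Compound 3 (`Nc1nc(NC2CCCC2)c2ncn(/C=C3/CC3(CO)CO)c2n1`) carries cyclopentylamino in place of pyrrolidin-1-yl on an aromatic carbon and awaits testing. Within the data shown here, no measured pair shows what such a swap does, so no step beyond the usual scatter is expected in this assay in either direction. The only figure to lean on is that of compound 1 at > 20000 nM and that figure is a limit. Compound 3 is expected at an estimated 16000 nM within a range of 5000 nM to 30000 nM on this scale.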

Compound 3, half-maximal cytotoxic concentration: > 20000 nM
Compound 3 gave a limit, no number (the forecaster's own chance of this, stated with the estimate: 60%); middle value at least 1.2-fold (0.09 log units) from the limit.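

In this assay, compound 1 and compound 3 each end at a limit of the assay and not a number, so no step between them can be read: the limit of > 20000 nM in this assay, at which 2 of the 3 values shown sit.

From the compounds shown here alone, what swapping pyrrolidin-1-yl for cyclopentylamino does to the result in this assay stays open, since compound 2 has no reported result there.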